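Triazolylpyridine Semicarbazones: Predicting a Trimethoxyphenyl Analogue

The source may report more compounds than this note shows. Statements on the series, on what has been measured and on what is new or still open speak of the compounds shown alone.

Compound 1 `CN(C)CCn1cnnc1-c1cc(Oc2ccc(NC(=O)N/N=C/c3ccc(Cl)cc3Cl)cc2F)ccn1` gives 390 nM in a functional assay on HT-29 cells (Homo sapiens) for cytotoxicity, read by MTT assay, with a stated time of 72 h; a higher number here means a weaker inhibitor, a lower number a stronger inhibitor.
Compound 2 `CN(C)CCn1cnnc1-c1cc(Oc2ccc(NC(=O)N/N=C/c3cc(C(C)(C)C)cc(C(C)(C)C)c3O)cc2F)ccn1` gives 680 nM in this assay.
Compound 3 `COc1ccc(OC)c(/C=N/NC(=O)Nc2ccc(Oc3ccnc(-c4nncn4CCN(C)C)c3)c(F)c2)c1` gives 2070 nM in this assay.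

Three compounds share one core and differ only in the aryl group attached to the carbon that carries a double bond to nitrogen. Compound 3 stands at the highest number of the three, meaning the weakest inhibition of cell growth; compound 2 is nearest, and compound 1 furthest away, both beyond the usual scatter of repeated measurements.

Compound 4 `COc1ccc(/C=N/NC(=O)Nc2ccc(Oc3ccnc(-c4nncn4CCN(C)C)c3)c(F)c2)c(OC)c1OC` has not yet been measured. It differs from compound 3 in one place: 2,3,4-trimethoxyphenyl in place of 2,5-dimethoxyphenyl on a carbon with a double bond to nitrogen. For the measured compounds named here, the only step measured on the same position is a 5.3-fold higher number from compound 1 to compound 3 (0.72 log units; beyond the scatter), which describes an exchange of halogens for methoxy groups rather than a further methoxy group on an already methoxylated ring. Going by the values given here, no measured step therefore bears directly on this change, and no direction can be inferred with confidence.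

On that basis compound 4 is expected to stay close to compound 3, with the step of a 1.2-fold higher number from compound 3 to compound 4 (0.08 log units; within the scatter) most likely within the scatter. The estimate for compound 4 in this assay is 2500 nM, with a range from 1000 nM to 6500 nM.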

Compound 4, half-maximal inhibitory concentration: 3970 nM
The estimate for compound 4 lay 1.6-fold (0.20 log units) below the measured number; the range from low to high includes it.
By their numbers in this assay, from the lowest: compounds 1 and 2 (each within the scatter of the next); then compounds 3 and 4 (each within the scatter of the next).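

In this assay, replacing 2,5-dimethoxyphenyl with 2,3,4-trimethoxyphenyl on the carbon with a double bond to nitrogen gives a step that stays within the usual scatter (a 1.9-fold higher number from compound 3 to compound 4 (0.28 log units; within the scatter)), so these two rings cannot be told apart by this measurement. Against the 2,4-dichlorophenyl of compound 1, the same 2,3,4-trimethoxyphenyl ring gives a large step beyond the scatter (a 10-fold higher number from compound 1 to compound 4 (1.01 log units; beyond the scatter)), which shows that a second methoxy-bearing ring also sits well apart from the chlorinated one at this position. No measurement shown here offers an explanation for either step.

The two methoxy-bearing rings differ both in how many methoxy groups they carry and in where those groups sit, so the compounds shown cannot separate the effect of the number from that of the placement. Going by these compounds, it also remains open how this position would respond to a plain phenyl ring, a ring carrying a single methoxy group, or a ring bearing an amine or a carboxylic acid.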